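Amino in Place of Hydrogen on the Core of Compound 1

A few compounds are considered here, and "the series" means these few. Any claim that something is new, unique, unknown or untested is made for them only; others in the source may bear on it.

Compound 1 `O=C(Nc1ccc(C[C@@H]2CC[C@H]([C@H](O)c3ccccc3)N2)cc1)[C@@H]1CCc2scnc21`: 80 mL/min/kg
Compound 2 `Cc1nc2c(s1)CC[C@H]2C(=O)Nc1ccc(C[C@@H]2CC[C@H]([C@H](O)c3ccccc3)N2)cc1`: 87 mL/min/kg

Of the compounds shown here, two sharing the core of compound 1 have been measured. In an ADME assay on the whole organism (plasma, strain Sprague-Dawley) for pharmacokinetics, with Rattus norvegicus as the target (on this read-out higher numbers stand for fast clearance and lower numbers for slow clearance), compound 1 gives 80 mL/min/kg, and compound 2 gives 87 mL/min/kg; the two numbers lie within the scatter of each other, so compound 1 stands at one of two values that cannot be told apart. For the measured compounds named here, the single measured step, a 1.1-fold higher number from compound 1 to compound 2 (0.04 log units; within the scatter), exchanged a substituent on an aromatic carbon of the core and moved the number no further than repeat measurements would.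

Compound 3 `Nc1nc2c(s1)CC[C@H]2C(=O)Nc1ccc(C[C@@H]2CC[C@H]([C@H](O)c3ccccc3)N2)cc1` differs from compound 1 in one place: amino in place of hydrogen on an aromatic carbon. Going by the values given here, no measured step puts an amino group anywhere on this core, so the only guidance is the step to compound 2, which shows that a small change on an aromatic carbon of the core left the clearance where it was. On that basis compound 3 is expected to show a 1.1-fold lower number from compound 1 to compound 3 (0.03 log units; within the scatter), a step within the scatter. The clearance of compound 3 is therefore estimated at 75 mL/min/kg, with a range from 45 mL/min/kg to 125 mL/min/kg.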

Compound 3, clearance: 50 mL/min/kg
Compound 3: middle estimate off by 1.5-fold (0.18 log units), on the high side, within the range that was stated.
By their numbers in this assay, from the lowest: compounds 3, 1 and 2 (each within the scatter of the next).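

In this assay, the aromatic carbon next to the ring nitrogen and next to the ring sulfur now has three groups to compare: hydrogen, methyl and amino. Amino in place of hydrogen gives a 1.6-fold lower number from compound 1 to compound 3 (0.20 log units; within the scatter) and amino in place of methyl gives a 1.7-fold lower number from compound 2 to compound 3 (0.24 log units; within the scatter), so both steps to the amino compound stay inside the scatter, and the earlier finding for methyl now extends to a second small group that, unlike methyl, brings a hydrogen-bond donor and acceptor. No information on why the clearance of these three compounds stays within the scatter of each other is available.

The compounds shown leave open whether this carbon stays as undemanding with anything larger or of a different kind, such as a dimethylamino group, an acetamido group or a carboxylic acid. They also leave open whether an amino group placed elsewhere on the shared core would keep the clearance within the scatter as it does here.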